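Furan for thiophene on the shared nucleoside core

This account rests on a few compounds, and the source may have more. Where it says the series, first, only, none or still open, it means among the compounds named here.

Measured so far in an ADME assay on BJ cells (Homo sapiens), read by MTT assay, with a stated time of 72 h; a lower number here means a stronger inhibitor, a higher number a weaker inhibitor:
compound 1 `Cc1ncnc2c1c(-c1ccoc1)cn2[C@@H]1O[C@H](CO)[C@@H](O)[C@H]1O` gives 89200 nM
compound 3 `Cc1ncnc2c1c(-c1ccsc1)cn2[C@@H]1O[C@H](CO)[C@@H](O)[C@H]1O` gives 96900 nM
compound 2 `CNc1ncnc2c1c(-c1ccsc1)cn2[C@@H]1O[C@H](CO)[C@@H](O)[C@H]1O` is reported only as a limit, > 100000 nM

Compound 3 and compound 2 share a core and differ by methylamino in place of methyl on an aromatic carbon; the step of an at least 1.0-fold lower number from compound 2 to compound 3 (0.01 log units; that floor lies within the scatter). Compound 2 sits at the limit of > 100000 nM in this assay, at which 1 of the 3 values shown sits. The step of a 1.1-fold lower number from compound 3 to compound 1 (0.04 log units; within the scatter) follows the change (furan-3-yl in place of thiophen-3-yl on an aromatic carbon). Compound 4 `CNc1ncnc2c1c(-c1ccoc1)cn2[C@@H]1O[C@H](CO)[C@@H](O)[C@H]1O` is not yet measured; it differs from compound 2 by furan-3-yl in place of thiophen-3-yl on an aromatic carbon, the same change at the same place. The step from compound 2 to compound 4 is expected to be a number no higher from compound 2 to compound 4 (the limit leaves the size open), resting on the measured step of a 1.1-fold lower number from compound 3 to compound 1 (0.04 log units; within the scatter). Compound 4 is expected to give 100000 nM in this assay, between 50000 nM and 200000 nM, and may well return only a limit.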

Compound 4, half-maximal inhibitory concentration: 96300 nM
The estimate for compound 4 lay 1.0-fold (0.02 log units) above the measured number; low and high end bracket the measured number.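

In this assay, furan-3-yl in place of thiophen-3-yl gives an at least 1.0-fold lower number from compound 2 to compound 4 (0.01 log units; that floor lies within the scatter), and the comparison between the two cores reaches only this far: the same change on two cores in this assay, a 1.1-fold lower number (0.04 log units; within the scatter) from compound 3 to compound 1 and an at least 1.0-fold lower number (0.01 log units; that floor lies within the scatter) from compound 2 to compound 4; the limit leaves it open whether they differ

From the compounds shown here alone, compound 2 is reported only as a limit, > 100000 nM, and the size of its step stays open.

Methylamino in place of methyl gives a 1.1-fold higher number from compound 1 to compound 4 (0.03 log units; within the scatter), so neither change shows a step beyond the scatter on the cores where it can be read, but equal step sizes across cores are not shown: the same change on two cores in this assay, an at least 1.0-fold lower number (0.01 log units; that floor lies within the scatter) from compound 2 to compound 3 and a 1.1-fold lower number (0.03 log units; within the scatter) from compound 4 to compound 1; the limit leaves it open whether they differ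

Going by these compounds, whether either place in the shared core can move the number beyond the scatter remains open. A primary amino group or a longer alkyl chain in place of methyl would test this.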